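A few compounds are considered here, and "the series" means these few. Any claim that something is new, unique, unknown or untested is made for them only; others in the source may bear on it.

Measured compounds:
compound 1 `COc1ccc(-c2cc(/C=C/C(=O)c3ccc(N)cc3)[nH]n2)cc1`: 5300 nM
compound 2 `COc1ccc(-c2cc(/C=C/C(=O)c3ccc(N)cc3)[nH]n2)cc1OC`: 7690 nM
compound 3 `COc1cc(C(=O)/C=C/c2cc(-c3cc(OC)c(OC)c(OC)c3)n[nH]2)cc(OC)c1OC`: 5670 nM

All three values come from a functional assay on U-251 cells (Homo sapiens) for inhibition, read by sulforhodamine B assay, with a stated time of 48 h; a lower number here means that less compound is tolerated, a higher number that more compound is tolerated. Compound 2 and compound 1 differ by hydrogen in place of methoxy on an aromatic carbon, and the step is a 1.5-fold lower number from compound 2 to compound 1 (0.16 log units; within the scatter). The difference between the core of compound 2 and the core of compound 3 is not broken down here. Compound 4 `COc1ccc(-c2cc(/C=C/C(=O)c3cc(OC)c(OC)c(OC)c3)[nH]n2)cc1OC` differs from compound 3 by hydrogen in place of methoxy on an aromatic carbon; the surroundings are not identical, since in compound 4 the place is also meta to a methoxy group, so this is the same kind of change, not the same change. Beside the earlier step, the step from compound 3 to compound 4 is expected to be a 1.3-fold lower number from compound 3 to compound 4 (0.10 log units; within the scatter), resting on compound 2 to compound 1 giving a 1.5-fold lower number from compound 2 to compound 1 (0.16 log units; within the scatter) and compound 3 giving 5670 nM. Compound 4 is therefore estimated at 4500 nM.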

Compound 4, concentration lethal to 50% of the cells: 5130 nM
Estimate against measurement, compound 4: 1.1-fold (0.06 log units) below; low and high end bracket the measured number.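

In this assay, hydrogen in place of methoxy on an aromatic carbon gives a 1.1-fold lower number from compound 3 to compound 4 (0.04 log units; within the scatter). Among these compounds, the two cores agree on this change as far as the data can tell: the same change on two cores in this assay, a 1.5-fold lower number (0.16 log units; within the scatter) from compound 2 to compound 1 and a 1.1-fold lower number (0.04 log units; within the scatter) from compound 3 to compound 4, 1.3-fold (0.12 log units) apart, within the scatter of two such steps This supports carrying the change between these two cores, but since neither step lies beyond the scatter, it shows only that the change has no resolvable effect on either core, and two pairs say nothing about any other core.

On these data alone, what a hydroxyl, a fluorine or an ethoxy group would give in that place stays open. So does whether any replacement there would move the number beyond the scatter.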